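A few compounds are considered here, and "the series" means these few. Any claim that something is new, unique, unknown or untested is made for them only; others in the source may bear on it.

Measured so far in an ADME assay on microsomes (Rattus norvegicus) for metabolic stability; on this read-out lower numbers stand for a shorter-lived compound and higher numbers for a longer-lived compound:
- compound 1 `O=C(c1ccccc1)N1CCC(C(=O)N2N=CCC2c2ccccc2)CC1`: 0.0833 h
- compound 2 `CC(C)(C)C(=O)N1CCSC1c1ccccc1`: 0.0533 h
- compound 3 `O=C(C1CCC1)N1N=CCC1c1ccccc1`: 0.583 h

Compound 1 holds the second-highest of the three numbers in this assay. Its nearest neighbour is compound 2, whose lower number sits within the scatter of repeated measurements, so the two cannot be told apart on these data. The furthest is compound 3, whose higher number lies beyond the scatter, making compound 3 the clearly longer-lived of the pair.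

The next compound on the path is compound 4 `O=C(C1CCN(c2ccccc2)CC1)N1N=CCC1c1ccccc1`. Relative to compound 1 the change is phenyl in place of benzoyl on an amine nitrogen in a ring. No pair of measured compounds shares this change, so nothing shown here gives its direction or size in this assay. Compound 2 and compound 3 differ from compound 1 in several places at once and cannot serve as a guide for this single swap.

With no shown step to lean on, the step from compound 1 to compound 4 is expected to be small, a 1.2-fold higher number from compound 1 to compound 4 (0.08 log units; within the scatter), with neither direction favoured and no clear move beyond the scatter. Compound 4 is therefore estimated at 0.1 h in this assay, within a range of 0.035 h to 0.3 h.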

Compound 4, half-life: 0.25 h
The estimate for compound 4 lay 2.5-fold (0.40 log units) below the measured number; the range from low to high includes it.
By their numbers in this assay, from the lowest: compounds 2 and 1 (each within the scatter of the next); then compound 4; then compound 3.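

Within the data shown here, on the amine nitrogen of the six-membered non-aromatic ring, phenyl in place of benzoyl gives a 3.0-fold higher number from compound 1 to compound 4 (0.48 log units; beyond the scatter) in this assay and is the only single-place step so far. The group on this nitrogen can therefore shift the half-life beyond the scatter, which compounds 2 and 3 could not show, as each differs from compound 1 in several places at once. The step removes the carbonyl and its hydrogen-bond acceptor along with two heavy atoms in all, but no measurement shown explains why the number rises.

One pair cannot separate the loss of the carbonyl from the change in the group as a whole, and a benzyl group, which keeps the carbon without the oxygen, or an acetyl group, which keeps the carbonyl without the aromatic ring, would pull these apart. Also open, on these data alone, is whether the higher number holds with a fluorine or a methoxy group on the phenyl ring, or with a pyridyl ring in its place.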